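From 5-Phenylpentyl to Pyridin-3-yl on the Carbonyl Carbon

The source may report more compounds than this note shows. Statements on the series, on what has been measured and on what is new or still open speak of the compounds shown alone.

In a functional assay on HeLa cells (Homo sapiens) for inhibition, read by sulforhodamine B assay, with a stated time of 48 h (a lower number here means a stronger inhibitor of growth, a higher number a weaker inhibitor of growth), compound 1 `O=C(CCCCCc1ccccc1)OCC1COCCOCCOCCOCCOCCO1` gives 79000 nM, the higher of the two actual numbers. Compound 3 `O=C(OCC1COCCOCCOCCOCCOCCO1)c1cccc(-c2ccc(Br)cc2)c1` gives 7800 nM, a lower number by a gap beyond the scatter. Compound 2 `CC/C=C/CC(=O)OCC1COCCOCCOCCOCCOCCO1` gives > 100000 nM, which is a limit of the assay and not a number. Compound 4 `O=C(OCC1COCCOCCOCCOCCOCCO1)c1cccnc1` differs from compound 1 as follows: pyridin-3-yl in place of 5-phenylpentyl on a carbonyl carbon. Within the data shown here, the one measured step that bears on this also replaces a phenyl-bearing chain: an at least 1.2-fold higher number from compound 1 to compound 2 (0.10 log units; that floor lies within the scatter). On that basis, the expected change in this assay is small and upward, not clearly beyond the scatter, with an estimated step of a 1.3-fold higher number from compound 1 to compound 4 (0.10 log units; within the scatter). For compound 4 the estimated value is 100000 nM, with an expected range of 40000 nM to 250000 nM.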

Compound 4, concentration for 50% growth inhibition: > 100000 nM
Compound 4 was reported as a limit; the forecaster's own chance of this, stated with the estimate: 50%; the middle value sits exactly at the limit.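

In this assay, pyridin-3-yl on the carbonyl carbon gives an at least 1.2-fold higher number from compound 1 to compound 4 (0.10 log units; that floor lies within the scatter), so this position now shows that an aromatic ring with one nitrogen, set directly on the carbonyl carbon, brings no stronger inhibition than the 5-phenylpentyl chain. As far as these compounds go, that floor lies within the scatter, and the true size of the step stays unknown. Compound 4 sits at a limit, as does compound 2, so the step between them cannot be read: the limit of > 100000 nM in this assay, at which 2 of the 4 values shown sit.

The compounds shown leave open whether an amine on the pyridine ring would bring the number below this limit. They also leave open whether a longer chain between that ring and the carbonyl carbon would do so.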